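Trifluoromethyl in place of fluoro on compound 1

The compounds below may be only part of what the source reports. "The series", "measured", "known", "first", "only" and "open" are said of these compounds alone.

Compound 1 `CN1C/C(=C\c2cccnc2)C(=O)/C(=C/c2ccccc2F)C1`: 4470 nM
Compound 2 `CN1C/C(=C\c2cccnc2)C(=O)/C(=C/c2cc([N+](=O)[O-])ccc2F)C1`: 11100 nM

Within the data shown here, in a functional assay on QGY-7703 cells (Homo sapiens) for cytotoxicity, read by MTT assay, with a stated time of 24 h (a higher number here means a weaker inhibitor, a lower number a stronger inhibitor), compound 1 gives 4470 nM, the lower of the two numbers so far, which makes it the stronger inhibitor of the pair. The unmeasured compound 3 `CN1C/C(=C\c2cccnc2)C(=O)/C(=C/c2ccccc2C(F)(F)F)C1` differs from compound 1 by one change: trifluoromethyl in place of fluoro on an aromatic carbon. Put simply, trifluoromethyl takes the place of fluoro on an aromatic carbon. Among the measured compounds shown here, only one measured step offers any guide, and only a loose one: a 2.5-fold higher number from compound 1 to compound 2 (0.40 log units; beyond the scatter). That modest step comes from a different change, nitro in place of hydrogen, so it supports only a tentative expectation of a small rise in this assay. The expected step is a 1.3-fold higher number from compound 1 to compound 3 (0.13 log units; within the scatter). For compound 3 the estimated value is 6000 nM, with an expected range of 2500 nM to 14000 nM.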

Compound 3, half-maximal inhibitory concentration: 2910 nM
Compound 3: middle estimate off by 2.1-fold (0.31 log units), on the high side, within the range that was stated.
By their numbers in this assay, from the lowest: compounds 3 and 1 (each within the scatter of the next); then compound 2.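

In this assay the change from fluoro to trifluoromethyl gives a 1.5-fold lower number from compound 1 to compound 3 (0.19 log units; within the scatter) and so cannot be told apart from repeat-measurement noise. At this position, ortho to a large group, a group of four heavy atoms therefore reads the same as one of a single heavy atom, at least for these two groups. Among these compounds, the earlier step, a 2.5-fold higher number from compound 1 to compound 2 (0.40 log units; beyond the scatter) and beyond the scatter, came from a different change, so this is the first look at this position, and nothing available explains the result.

On these data alone, whether an amine or a carboxylic acid at this same position would also stay level with compound 1 remains open. So does whether a longer chain, such as a butyl group, would still read the same in this assay or would move the number beyond the scatter.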